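The source may report more compounds than this note shows. Statements on the series, on what has been measured and on what is new or still open speak of the compounds shown alone.

Three compounds sharing one core differ only in the group on the aromatic ring of the sulfonamide. Compound 1 `COc1ncc(-c2ccn3nc(NC(C)=O)nc3c2)cc1NS(=O)(=O)c1ccc(Cl)cc1` carries a chloro there, and in a functional assay on MCF7 cells (Homo sapiens) for antiproliferative activity, read by MTT assay, with a stated time of 48 h (a higher number here means a weaker inhibitor, a lower number a stronger inhibitor), compound 1 gives 1240 nM. Compound 2 `COc1ncc(-c2ccn3nc(NC(C)=O)nc3c2)cc1NS(=O)(=O)c1ccc(C)cc1` carries a methyl, and in this assay compound 2 gives 1360 nM. Compound 3 `COc1ncc(-c2ccn3nc(NC(C)=O)nc3c2)cc1NS(=O)(=O)c1ccc(F)cc1` carries a fluoro, and in this assay compound 3 gives 1730 nM. The three numbers sit close together: the step of a 1.1-fold higher number from compound 1 to compound 2 (0.04 log units; within the scatter), the step of a 1.4-fold higher number from compound 1 to compound 3 (0.14 log units; within the scatter) and the step of a 1.3-fold higher number from compound 2 to compound 3 (0.10 log units; within the scatter) are all within the scatter, so compound 3 stands among its two neighbours with no separation that the assay can resolve.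

Compound 4 `COc1ncc(-c2ccn3nc(N)nc3c2)cc1NS(=O)(=O)c1ccc(F)cc1` is reached from compound 3 by a change of a different kind, (hydrogen in place of acetyl on a nitrogen on an aromatic ring), that is, acetamido to amino. Going by the values given here, none of the measured steps touches this part of the molecule; all three concern the group on the sulfonyl-bearing ring, and all three are within the scatter. Among the compounds with values here, there is therefore no measured step that bears on the change from compound 3 to compound 4, and the expectation rests on the absence of a guide rather than on a trend. Compound 4 is estimated at 2500 nM, with a range from 500 nM to 15000 nM, which would mean an expected step of a 1.4-fold higher number from compound 3 to compound 4 (0.16 log units; within the scatter).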

Compound 4, half-maximal inhibitory concentration: 920 nM
Compound 4: middle estimate off by 2.7-fold (0.43 log units), on the high side; low and high end bracket the measured number.
By their numbers in this assay, from the lowest: compounds 4, 1, 2 and 3 (each within the scatter of the next).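

With hydrogen in place of acetyl on a nitrogen on an aromatic ring, this assay gives a 1.9-fold lower number from compound 3 to compound 4 (0.27 log units; within the scatter), the first step shown at this position rather than on the group of the sulfonamide ring, and it lies within the scatter, so the assay does not separate the acetamido compound from the amino compound. Going by these compounds alone, the acetyl is thus not needed for activity in the range of this small set, since compound 4, with its free amino group, stands among the same numbers as the three acetamido compounds, although this reading rests on the single fluoro pair. No measurement given here offers an explanation for this result, and the closeness of the two compounds cannot be traced to any property of the acetyl group.

The compounds shown leave open whether the same exchange would read alike with the chloro or methyl group on the sulfonamide ring. They also leave open how a longer acyl chain such as propanoyl, a cyclopropanecarbonyl group or a simple methyl on that nitrogen would stand in this assay.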